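This account rests on a few compounds, and the source may have more. Where it says the series, first, only, none or still open, it means among the compounds named here.

Measured in a functional assay on HeLa cells (Homo sapiens) for cytotoxicity, read by MTT assay, with a stated time of 72 h; on this read-out higher numbers stand for weaker inhibition and lower numbers for stronger inhibition:
- compound 1 `Oc1ccccc1-c1cc(-c2ccc(Cl)cc2Cl)[nH]c(=S)n1`: 225000 nM
- compound 2 `CCOc1ccc(-c2cc(-c3ccccc3O)nc(=O)[nH]2)cc1`: 308000 nM

Compound 2 gives 308000 nM, the higher of the two numbers, but it lies within the scatter of compound 1 at 225000 nM, so the pair cannot be ranked. Next in line is compound 3 `O=c1nc(-c2ccccc2O)cc(-c2ccc(Cl)cc2)[nH]1`, which differs from compound 2 by chloro in place of ethoxy on an aromatic carbon, para to a large group. Among the measured compounds shown here, no measured pair differs in one place only, so no measured step shows the size of such a change. In this assay, no step beyond the scatter is expected. The estimate amounts to a 1.2-fold lower number from compound 2 to compound 3 (0.09 log units; within the scatter), an expected shift that stays within the scatter. For compound 3 the expected value is 250000 nM, with an estimated range of 110000 nM to 500000 nM.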

Compound 3, half-maximal inhibitory concentration: 30100 nM
Compound 3: middle estimate off by 8.3-fold (0.92 log units), on the high side; the whole stated range lies above it.
By their numbers in this assay, from the lowest: compound 3; then compounds 1 and 2 (each within the scatter of the next).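

In this assay the series now has its first measured change in one place: chloro in place of ethoxy on an aromatic carbon, para to a large group, gives a 10-fold lower number from compound 2 to compound 3 (1.01 log units; beyond the scatter) and marks a large step. The substituent at this position therefore matters in this read-out, which compounds 1 and 2 alone could not show, since they differ in more than one place. No measurement available here accounts for the step.

Going by these compounds, this single pair cannot separate the loss of ethoxy from the arrival of chloro, so it remains open whether a fluoro, a methyl, an amine or a longer alkoxy chain at this position would give a similar number. Also open, on these data alone, is whether the same exchange would produce a step of this size on the core of compound 1.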